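The source may report more compounds than this note shows. Statements on the series, on what has been measured and on what is new or still open speak of the compounds shown alone.

Compound 3 `O=C(c1ccccc1F)N1CCc2oc(-c3ccc(F)cn3)nc2C1` stands second highest of the three numbers in a functional assay on HEK293 cells for negative allosteric modulation of metabotropic glutamate receptor 5 (Homo sapiens), read by fluorescence and calcium flux, with a stated time of 2 min (on this read-out higher numbers stand for weaker inhibition and lower numbers for stronger inhibition), where compound 3 gives 58 nM. Compound 1 `O=C(c1ccccc1)N1CCc2oc(-c3ccc(Cl)cn3)nc2C1` gives 32 nM in this assay, within the scatter of compound 3, while compound 2 `O=C(c1ccccc1)N1CCc2oc(-c3ccc(Br)cn3)nc2C1` gives 174 nM, a gap beyond the scatter. The single-change step seen so far is a 5.4-fold higher number from compound 1 to compound 2 (0.74 log units; beyond the scatter), a halogen swap on an aromatic carbon of the shared core, not on the ring attached to the carbonyl carbon. Compound 4 `COc1cccc(C(=O)N2CCc3oc(-c4ccc(F)cn4)nc3C2)c1` differs from compound 3 by 3-methoxyphenyl in place of 2-fluorophenyl on a carbonyl carbon. Going by the values given here, no measured pair varies this ring, so no step bears on the change and no shift beyond the scatter is expected in this assay, with wide uncertainty either way. Compound 4 is therefore estimated at 80 nM in this assay, range 25 nM to 300 nM, an expected step of a 1.4-fold higher number from compound 3 to compound 4 (0.14 log units; within the scatter).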

Compound 4, half-maximal inhibitory concentration: 157 nM
Compound 4: middle estimate off by 2.0-fold (0.29 log units), on the low side; the range from low to high includes it.
By their numbers in this assay, from the lowest: compounds 1 and 3 (each within the scatter of the next); then compounds 4 and 2 (each within the scatter of the next).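

The ring on the carbonyl carbon is not silent in this assay: 3-methoxyphenyl in place of 2-fluorophenyl gives a 2.7-fold higher number from compound 3 to compound 4 (0.43 log units; beyond the scatter) and so moves the number with the rest of the molecule unchanged. Going by these compounds alone, the earlier step concerned only a halogen on the shared core, so this is the first reading at this position. No measured evidence bears on the origin of this step.

Still open, as far as these compounds go, is whether the group itself or its place on the ring carries the step, as 2-fluorophenyl and 3-methoxyphenyl differ in both. Also open, from the compounds shown here alone, is how a phenyl ring bearing an amine or a carboxylic acid would read on this carbonyl carbon.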